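The source may hold more compounds than are shown below. What is called first, only, known or untested is meant among the compounds shown, and "the series" means these compounds.

Three thiosemicarbazones built on one shared core have been measured in a functional assay on NCI-H460 cells (Homo sapiens) for inhibition, read by sulforhodamine B assay, with a stated time of 48 h; a higher number here means a weaker inhibitor of growth, a lower number a stronger inhibitor of growth. Compound 1 `COc1ccc(/C=N/NC(=S)NC(C)(C)[C@H]2CC=C(C)CC2)cc1` gives 22500 nM. Compound 3 `CC1=CC[C@H](C(C)(C)NC(=S)N/N=C/c2ccccc2Cl)CC1` gives 64500 nM. For compound 2 `CC1=CC[C@H](C(C)(C)NC(=S)N/N=C/c2ccc(O)cc2)CC1` the assay reports only a limit, > 100000 nM. Among the two plain numbers compound 3 has the higher one; the nearest is compound 1, with the step of a 2.9-fold higher number from compound 1 to compound 3 (0.46 log units; beyond the scatter), which comes from 2-chlorophenyl in place of 4-methoxyphenyl on a carbon with a double bond to nitrogen as a change of the aromatic group on the carbon double-bonded to nitrogen. Against compound 2 the step is an at least 1.5-fold lower number from compound 2 to compound 3 (0.19 log units; that floor lies within the scatter), and its floor says little.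

Compound 4 `CC1=CC[C@H](C(C)(C)NC(=S)N/N=C/c2ccco2)CC1` has not yet been measured. It differs from compound 3 by furan-2-yl in place of 2-chlorophenyl on a carbon with a double bond to nitrogen. Within the data shown here, the only measured steps that alter the same aromatic group are a 2.9-fold higher number from compound 1 to compound 3 (0.46 log units; beyond the scatter) and an at least 1.5-fold lower number from compound 2 to compound 3 (0.19 log units; that floor lies within the scatter); both are modest or undecided, and none involves a five-membered ring, so the direction of the new step is open. A modest change in either direction, or none beyond the scatter, is therefore expected in this assay. Compound 4 is estimated to give 50000 nM, with a range from 15000 nM to 150000 nM. The expected step is a 1.3-fold lower number from compound 3 to compound 4 (0.11 log units; within the scatter).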

Compound 4, concentration for 50% growth inhibition: 13500 nM
Compound 4: the middle estimate sits 3.7-fold (0.57 log units) above what was measured; measured number below the stated range.
By their numbers in this assay, from the lowest: compounds 4 and 1 (each within the scatter of the next); then compound 3. At a limit, above all of these: compound 2.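

The earlier compounds shown here carried only six-membered aromatic rings on the carbon with a double bond to nitrogen, and in this assay furan-2-yl now shows that a five-membered aromatic ring with one hetero atom can stand there, with a 4.8-fold lower number from compound 3 to compound 4 (0.68 log units; beyond the scatter) as the step from the 2-chlorophenyl compound. The ring swap does not simply give a higher number either, since a 1.7-fold lower number from compound 1 to compound 4 (0.22 log units; within the scatter) means that compound 4 and compound 1 cannot be told apart here, even though furan-2-yl and 4-methoxyphenyl differ in ring size and in atom count. The step of an at least 7.4-fold lower number from compound 2 to compound 4 (0.86 log units; beyond the scatter) gives only a floor for this change, and compound 2 stands as a limit rather than a number: the limit of > 100000 nM in this assay, at which 1 of the 4 values shown sits.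

With one five-membered ring in the set, the compounds shown cannot separate the effect of the smaller ring from that of its oxygen, and a thiophene ring, with sulfur in place of that oxygen, or an unsubstituted phenyl ring would bear on this. They also leave open how an open-chain group at this place, such as a simple alkyl chain or one carrying an amine, would compare with these aromatic rings.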